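The source may report more compounds than this note shows. Statements on the series, on what has been measured and on what is new or still open speak of the compounds shown alone.

Measured compounds:
- Compound 1 `CC(C)(C)OC(=O)N1CCC(c2nc(COc3ccc(/C=C4\CC(=O)NC4=O)cc3F)cs2)CC1`: 157 nM
- Compound 2 `CCc1cnc(N2CCC(c3nc(COc4ccc(/C=C5\CC(=O)N(CCNC(=O)OC(C)(C)C)C5=O)cc4F)cs3)CC2)nc1`: no result reported, "not determined" (no result reported)

For the measured compounds named here, compound 2 has no number in a functional assay on cells for agonist activity at Glucose-dependent insulinotropic receptor (Homo sapiens), read by a luciferase reporter, with a stated time of 6 h (on this read-out higher numbers stand for an effect only at larger amounts of compound and lower numbers for an effect already at smaller amounts), so its standing cannot be placed; the only measured point is compound 1, which in this assay gives 157 nM.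

Compound 3 `CCc1cnc(N2CCC(c3nc(COc4ccc(/C=C5\CC(=O)NC5=O)cc4F)cs3)CC2)nc1` is the next compound to be measured in this assay. Relative to compound 2 the change is hydrogen in place of 2-((tert-butoxycarbonyl)amino)ethyl on an amide-type nitrogen in a ring. Going by the values given here, no pair of measured compounds shows this change, so the size of the step in this assay is not known from the data. With the ring nitrogen left as the amide hydrogen, as in compound 1, and the rest of compound 2 kept, the expectation is a half-maximal effective concentration near that of compound 1 or somewhat lower, without a directional claim beyond the scatter.

Compound 3 is expected to give 60 nM in this assay, with a range from 10 nM to 400 nM.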

Compound 3, half-maximal effective concentration: 49 nM
Compound 3: middle estimate off by 1.2-fold (0.09 log units), on the high side, and the stated range covers the measured number.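

In this assay the amine nitrogen in a ring now has its first measured comparison: a 3.2-fold lower number from compound 1 to compound 3 (0.51 log units; beyond the scatter) is a modest step beyond the scatter, with 5-ethylpyrimidin-2-yl in place of tert-butoxycarbonyl and the amide hydrogen shared by both compounds. Compound 1 alone could not show whether this position accepts another group, and this pair shows that the replacement keeps activity and gives a lower number. No measured evidence bears on the reason for this step, and the step from compound 2 to compound 3 on the amide-type nitrogen in a ring cannot be read.

Open, as far as these compounds go, is how pyrimidin-2-yl without the ethyl group or with a longer chain in its place would compare. Also open, from the compounds shown here alone, is how a group on the amide-type nitrogen, such as a 2-aminoethyl or a carboxymethyl chain, would read.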